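A few compounds are considered here, and "the series" means these few. Any claim that something is new, unique, unknown or untested is made for them only; others in the source may bear on it.

Measured compounds in an assay on CHO cells for displacement of a labelled ligand from adenosine receptor A1 (Homo sapiens), with a stated time of 60 min, tested at 10 uM; on this read-out higher numbers stand for more inhibition at the one concentration tested (going by the name of the read-out) and lower numbers for less inhibition:

Compound 1 `CCCCC#Cc1nc(NCc2cccc(Br)c2)c2ncn([C@@H]3OC[C@@H](O)[C@H]3O)c2n1`: 12%
Compound 2 `CCCCC#Cc1nc(NCc2cccc(Br)c2)c2ncn([C@@H]3SC[C@@H](O)[C@H]3O)c2n1`: 12%
Compound 3 `CCCCC#Cc1nc(NCc2cccc(F)c2)c2ncn([C@@H]3OC[C@@H](O)[C@H]3O)c2n1`: 9%

All three sit close together. The move no change at the digits printed from compound 1 to compound 2 (within the scatter) shows the change of the sugar-like ring making no difference here, and the move a number 3 percentage points lower from compound 1 to compound 3 (within the scatter) is also within scatter, so compound 3, though its number is the lowest of the three, cannot be called weaker than the others.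

Compound 4 `CCCCC#Cc1nc(NCc2cccc(I)c2)c2ncn([C@@H]3OC[C@@H](O)[C@H]3O)c2n1` differs from compound 3 by iodo in place of fluoro on an aromatic carbon. Among the compounds with values here, the only step bearing on this is the halogen swap a number 3 percentage points lower from compound 1 to compound 3 (within the scatter), which was small; bromo and fluoro gave numbers that cannot be told apart. An iodo group is therefore expected to leave this assay essentially unchanged, with no step beyond the scatter expected: a number 3 percentage points higher from compound 3 to compound 4 (within the scatter). Compound 4 is estimated at 12%, range 2% to 24%.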

Compound 4, a percentage reported as inhibition, at one concentration (the size of the read-out at that concentration, not a potency): 18%
Compound 4: middle estimate off by 6 percentage points, on the low side; the range from low to high includes it.
By their numbers in this assay, from the lowest: compounds 3, 1, 2 and 4 (each within the scatter of the next).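

Iodo joins bromo and fluoro on this aromatic carbon in this assay, and neither step leaves the scatter: a number 9 percentage points higher from compound 3 to compound 4 (within the scatter), and a number 6 percentage points higher from compound 1 to compound 4 (within the scatter). From 3-fluorobenzyl to 3-iodobenzyl, the halogens shown therefore give no readable order at the one concentration tested. Nothing measured here accounts for the small differences in the numbers.

On these data alone, whether a methoxy group or an amine on this carbon would move the number beyond the scatter remains open. So does whether iodo behaves the same with the 3,4-dihydroxythiolan-2-yl ring.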